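Working notes: the step from compound 3 to compound 4

The source may hold more compounds than are shown below. What is called first, only, known or untested is meant among the compounds shown, and "the series" means these compounds.

Compound 1 `C/C=C/C(=O)Nc1cccc(-c2nc3ccccc3s2)c1`. In an ADME assay on HEK293 cells (Homo sapiens) for inhibition, with a stated time of 72 h (a higher number here means that more compound is needed for the effect, a lower number that less compound is needed), compound 1 gives > 25000 nM; this is a limit of the assay, not a number.
Compound 2 `O=C(O)/C=C/C(=O)Nc1cccc(-c2nc3ccccc3s2)c1`. In this assay compound 2 gives > 25000 nM; this too is a limit, not a number.
Compound 3 `O=C(CCl)Nc1cccc(-c2nc3ccccc3s2)c1`. In this assay compound 3 gives 10000 nM.

Within the data shown here, compound 3 is the only compound of the three with a measured number; the other two sit at the limit of > 25000 nM in this assay, at which 2 of the 3 values shown sit. The steps into compound 3 are an at least 2.5-fold lower number from compound 1 to compound 3 (0.39 log units; beyond the scatter) and an at least 2.5-fold lower number from compound 2 to compound 3 (0.39 log units; beyond the scatter), both swapping the whole group on the carbonyl carbon. The step that the two limits leave unreadable from compound 1 to compound 2 is not readable.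

Compound 4 `CC(Cl)C(=O)Nc1cccc(-c2nc3ccccc3s2)c1` differs from compound 3 by methyl in place of hydrogen on a saturated chain carbon bound to a carbonyl carbon and a chlorine atom. Among the measured compounds shown here, none of the measured steps touches that position; they only show that the (chloromethyl)carbonyl of compound 3 gives the lowest number seen. With nothing measured on the saturated chain carbon itself, the expectation for compound 4 is a number close to compound 3, with a small shift upward allowed, a 1.8-fold higher number from compound 3 to compound 4 (0.26 log units; within the scatter), and a fair chance that only a limit results. The estimate for compound 4 is 18000 nM, with a range from 6000 nM to 50000 nM.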

Compound 4, half-maximal effective concentration: > 25000 nM
Compound 4 was reported as a limit; the forecaster's own chance of this, stated with the estimate: 40%; middle value at least 1.3-fold (0.14 log units) from the limit.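

In this assay, the saturated chain carbon bound to a carbonyl carbon and a chlorine atom does not tolerate every change: methyl in place of hydrogen gives an at least 2.5-fold higher number from compound 3 to compound 4 (0.39 log units; beyond the scatter). Among these compounds, this is the first measured change at this carbon, whereas the earlier steps swapped the whole group on the carbonyl carbon. Within this set, the measured number now rests on the chloromethyl group of compound 3 alone: the limit of > 25000 nM in this assay, at which 3 of the 4 values shown sit.

The steps to compound 4 from compound 1 and from compound 2 cannot be read, and the value of compound 4 is a limit, not a number, which leaves the full size of the step from hydrogen to methyl open. Also open, going by these compounds, is whether a fluorine or bromine atom in place of the chlorine, or a longer chain in place of the methyl, would bring the number back toward that of compound 3.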